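The compounds below may be only part of what the source reports. "The series", "measured", "known", "first", "only" and "open" are said of these compounds alone.

In a functional assay on the whole organism for inhibition, with Scenedesmus acutus as the target (a lower number here means a stronger inhibitor, a higher number a weaker inhibitor), compound 1 `O=C(O)c1cc(N2C(=O)C3=C(CCCC3)C2=O)c(F)cc1Cl` gives 1000 nM and compound 2 `COC(=O)c1cc(N2C(=O)C3=C(CCCC3)C2=O)c(F)cc1Cl` gives 67.6 nM as the lower of the two numbers. Within the data shown here, the single measured step is a 15-fold lower number from compound 1 to compound 2 (1.17 log units; beyond the scatter) for methyl in place of hydrogen on an oxygen next to a carbonyl group, a large change. Compound 3 `CCCOC(=O)c1cc(N2C(=O)C3=C(CCCC3)C2=O)c(F)cc1Cl` differs from compound 2 by ethyl in place of hydrogen on a saturated chain carbon bound to an oxygen next to a carbonyl group with methoxycarbonyl becoming propoxycarbonyl. Among the measured compounds shown here, the measured step bears on this only loosely: it does not lengthen a chain, and no measured pair tests chain length. A change within the scatter is expected in this assay with no direction favoured. The expected move is a 1.1-fold lower number from compound 2 to compound 3 (0.05 log units; within the scatter) as an estimate only. For compound 3 the estimated value is 60 nM with an expected range from 20 nM to 180 nM at this stage.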

Compound 3, half-maximal inhibitory concentration: 33.1 nM
Compound 3: middle estimate off by 1.8-fold (0.26 log units), on the high side, and the stated range covers the measured number.
By their numbers in this assay, from the lowest: compound 3; then compound 2; then compound 1.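

In this assay, going from methoxycarbonyl to propoxycarbonyl gives a 2.0-fold lower number from compound 2 to compound 3 (0.31 log units; beyond the scatter) and shows that the number still moves once the acid is esterified, though by far less than the first esterification step. Propyl in place of hydrogen on the oxygen gives a 30-fold lower number from compound 1 to compound 3 (1.48 log units; beyond the scatter) and places the propyl ester lowest of the three compounds. No measured evidence accounts for either step.

Going by these compounds, whether a butyl or longer chain lowers the number further remains open. On these data alone, a branched isopropyl ester and an amide in place of the ester are also open.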